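Replacing the trimethoxyphenyl group of compound 1

A few compounds are considered here, and "the series" means these few. Any claim that something is new, unique, unknown or untested is made for them only; others in the source may bear on it.

- compound 1 `COc1cc(/C=C/C(=O)Nc2cc3c(Nc4ccc(F)c(Cl)c4)ncnc3cc2O[C@H]2CCOC2)cc(OC)c1OC`: 24500 nM
- compound 2 `COc1ccc(/C=C/C(=O)Nc2cc3c(Nc4ccc(F)c(Cl)c4)ncnc3cc2OC)cc1`: "not determined" (no result reported)
- compound 3 `COc1ccc(/C=C/C(=O)Nc2cc3c(Nc4ccc(F)c(Cl)c4)ncnc3cc2OC)c(OC)c1`: "not determined" (no result reported)

Going by the values given here, in a functional assay on HeLa cells (Homo sapiens) for cytotoxicity, read by MTT assay, with a stated time of 72 h (on this read-out lower numbers stand for stronger inhibition and higher numbers for weaker inhibition), compound 1 gives 24500 nM, and this is the only number available. Neither compound 2 nor compound 3 has a result, so compound 1 cannot be ranked against anything. Compound 4 `O=C(/C=C/c1ccc(F)cc1Cl)Nc1cc2c(Nc3ccc(F)c(Cl)c3)ncnc2cc1O[C@H]1CCOC1` keeps the core of compound 1 and has 2-chloro-4-fluorophenyl in place of 3,4,5-trimethoxyphenyl on a double-bonded chain carbon bound to a double-bonded chain carbon. Among the compounds with values here, no measured pair shows what such an exchange does in this assay. The expected change is therefore small, leaning towards stronger inhibition but not clearly beyond the scatter, with an estimated 1.6-fold lower number from compound 1 to compound 4 (0.21 log units; within the scatter). Compound 4 is estimated at 15000 nM, with an expected range from 4000 nM to 50000 nM.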

Compound 4, half-maximal inhibitory concentration: 37500 nM
Compound 4: middle estimate off by 2.5-fold (0.40 log units), on the low side; the measured number falls inside the stated range.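

In this assay, going by these compounds alone, the first measured exchange at this position gives a 1.5-fold higher number from compound 1 to compound 4 (0.18 log units; within the scatter) with 2-chloro-4-fluorophenyl in place of 3,4,5-trimethoxyphenyl. Thus a group with 0 hydrogen-bond acceptors and one with 3 on this double-bonded chain carbon leave the number within the scatter, and both compounds stay weak on this read-out. Nothing measured accounts for this result. As far as these compounds go, whether an amine or a carboxylic acid in place of 3,4,5-trimethoxyphenyl would move the number beyond the scatter stays open.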